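The compounds below may be only part of what the source reports. "The series", "measured", "known", "first", "only" and "open" are said of these compounds alone.

In a functional assay on MDA-MB-231 cells (Homo sapiens) for antiproliferative activity, read by MTT assay, with a stated time of 48 h (on this read-out lower numbers stand for stronger inhibition and higher numbers for weaker inhibition), compound 1 `C=CS(=O)(=O)N1CCN(c2ncnc3ccc(-c4ccccc4)cc23)CC1` gives 47900 nM and compound 2 `C=CS(=O)(=O)N1CCN(c2ncnc3sc(-c4ccc(C#N)cc4)cc23)CC1` gives 8050 nM. Compound 2 thus holds the lower of the two numbers, by a gap beyond the usual scatter. Compound 3 `C=CS(=O)(=O)N1CCN(c2ncnc3sc(-c4cc(Br)cnc4F)cc23)CC1` changes one group of compound 2, on an aromatic carbon next to the ring sulfur: 5-bromo-2-fluoropyridin-3-yl in place of 4-cyanophenyl (5-bromo-2-fluoropyridin-3-yl in place of 4-cyanophenyl on an aromatic carbon). Within the data shown here, no measured pair shows what such a swap does, so no step beyond the scatter, in either direction, is expected in this assay. The estimated change is a 1.1-fold higher number from compound 2 to compound 3 (0.05 log units; within the scatter). The expected value for compound 3 is 9000 nM, with an estimated range from 2500 nM to 32000 nM.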

Compound 3, half-maximal inhibitory concentration: 24100 nM
For compound 3 the middle estimate is 2.7-fold (0.43 log units) below the measured one; measured number inside the range.
By their numbers in this assay, from the lowest: compound 2; then compounds 3 and 1 (each within the scatter of the next).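

In this assay the swap of 4-cyanophenyl for 5-bromo-2-fluoropyridin-3-yl on an aromatic carbon next to the ring sulfur gives a 3.0-fold higher number from compound 2 to compound 3 (0.48 log units; beyond the scatter) and counts as a modest loss. Among these compounds, this is the first sign that the group at this position affects the read-out, as these two groups are not interchangeable here. Nothing measured here accounts for the step.

Among the compounds shown here, the single swap leaves open whether the bromine, the fluorine or the ring nitrogen drives the loss. On these data alone, how an amine or a carboxylic acid on the ring at this position would compare also remains open.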